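The source may report more compounds than this note shows. Statements on the series, on what has been measured and on what is new or still open speak of the compounds shown alone.

Measured so far in a functional assay on T47D cells (Homo sapiens) for inhibition; a higher number here means a weaker inhibitor, a lower number a stronger inhibitor: compound 1 `Oc1cccc(-c2cc(-c3ccccc3F)cc(-c3ccccc3O)n2)c1` gives 24200 nM; compound 2 `Oc1cccc(-c2cc(-c3ccccc3C(F)(F)F)cc(-c3ccccc3O)n2)c1` gives 5680 nM; compound 3 `Oc1ccccc1-c1cc(-c2ccccc2OC(F)(F)F)cc(-c2ccccc2O)n1` gives 1730 nM.

Compound 3 stands lowest of the three numbers in this assay, with compound 2 nearest and compound 1 furthest. Compound 4 `Oc1cccc(-c2cc(-c3ccccc3OC(F)(F)F)cc(-c3ccccc3O)n2)c1` differs from compound 3 in one place: 3-hydroxyphenyl in place of 2-hydroxyphenyl on an aromatic carbon. Within the data shown here, no measured step bears directly on this change; the one step on record, a 4.3-fold lower number from compound 1 to compound 2 (0.63 log units; beyond the scatter), concerns a different position and a different pair of groups. Compounds 2 and 3 differ in two places at once, so their values alone cannot separate the two changes. Compound 4 is therefore expected to land near compound 3, with a modest step of a 1.7-fold higher number from compound 3 to compound 4 (0.24 log units; within the scatter) of uncertain direction, estimated at 3000 nM (range 1000 nM to 9000 nM).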

Compound 4, half-maximal inhibitory concentration: 2680 nM
The estimate for compound 4 lay 1.1-fold (0.05 log units) above the measured number; measured number inside the range.
By their numbers in this assay, from the lowest: compounds 3 and 4 (each within the scatter of the next); then compound 2; then compound 1.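

In this assay, a 1.5-fold higher number from compound 3 to compound 4 (0.19 log units; within the scatter), so on this carbon next to the ring nitrogen, 3-hydroxyphenyl and 2-hydroxyphenyl cannot be told apart. With 3-hydroxyphenyl held in place, the other substituent does register: trifluoromethoxy in place of trifluoromethyl gives a 2.1-fold lower number from compound 2 to compound 4 (0.33 log units; beyond the scatter), and trifluoromethoxy in place of fluoro gives a 9.0-fold lower number from compound 1 to compound 4 (0.96 log units; beyond the scatter). Nothing available explains these steps.

As far as these compounds go, whether the two hydroxyphenyl groups also match alongside fluoro or trifluoromethyl remains open. So does whether an amine or a methoxy group could replace the hydroxyl here.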